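Heteroaryl exchange on the shared core: outlook for compound 4

The compounds below may be only part of what the source reports. "The series", "measured", "known", "first", "only" and "open" are said of these compounds alone.

Measured compounds in an in vitro assay on CHO cells for displacement of a labelled ligand from Bombesin receptor subtype-3 (Homo sapiens), read by scintillation counting, with a stated time of 2 h; on this read-out higher numbers stand for weaker inhibition and lower numbers for stronger inhibition:
compound 1 `CCC(C)(C)Cc1c[nH]c(CCc2ccc(-c3cccc(C)n3)cc2)n1` — 6.3 nM
compound 2 `CCC(C)(C)Cc1c[nH]c(CCc2ccc(-c3ccc(F)cn3)cc2)n1` — 19 nM
compound 3 `CCC(C)(C)Cc1c[nH]c(CCc2ccc(-c3csnn3)cc2)n1` — 45 nM

Compound 3 stands at the highest number of the three in this assay; compound 2 is nearest to it and compound 1 furthest, as the step of a 7.1-fold higher number from compound 1 to compound 3 (0.85 log units; beyond the scatter) shows. The steps of a 3.0-fold higher number from compound 1 to compound 2 (0.48 log units; beyond the scatter) and a 2.4-fold higher number from compound 2 to compound 3 (0.37 log units; beyond the scatter) both lie beyond the scatter yet stay modest, so exchanging the group on this aromatic carbon has so far moved the read-out by modest amounts only.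

Compound 4 `CCC(C)(C)Cc1c[nH]c(CCc2ccc(-c3ccns3)cc2)n1` differs from compound 3 in one place: 1,2-thiazol-5-yl in place of 1,2,3-thiadiazol-4-yl on an aromatic carbon. For the measured compounds named here, no measured step exchanges one five-membered aromatic ring for another; every step so far involves at least one 6-methylpyridin-2-yl or 5-fluoropyridin-2-yl group, so they bear on this change only indirectly, by showing that the size of such steps has been modest. A step within or close to the scatter is therefore expected for compound 4, direction open. The estimate for compound 4 in this assay is 35 nM, with a range from 12 nM to 110 nM, which corresponds to an expected step of a 1.3-fold lower number from compound 3 to compound 4 (0.11 log units; within the scatter).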

Compound 4, half-maximal inhibitory concentration: 11 nM
For compound 4 the middle estimate is 3.2-fold (0.50 log units) above the measured one; measured number outside the range, below it.
By their numbers in this assay, from the lowest: compounds 1, 4 and 2 (each within the scatter of the next, the first and the last beyond it); then compound 3.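

In this assay, for the compounds shown here, the step of a 4.1-fold lower number from compound 3 to compound 4 (0.61 log units; beyond the scatter) is the first between two five-membered aromatic rings, and it shows that this aromatic carbon, para to a large group, separates 1,2-thiazol-5-yl from 1,2,3-thiadiazol-4-yl even though both have the same number of heavy atoms and a ring nitrogen gives way to carbon. A five-membered ring at this position therefore does not by itself go with the highest number in the set, since a 1.7-fold lower number from compound 2 to compound 4 (0.24 log units; within the scatter) and a 1.7-fold higher number from compound 1 to compound 4 (0.24 log units; within the scatter) both lie within the scatter, leaving compound 4 unresolved from either pyridine compound on this read-out. Nothing on hand accounts for the size of the step between the two five-membered rings.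

Still open, as far as these compounds go, is whether the step follows the ring's hetero atoms or its point of attachment, which a 1,3-thiazol-2-yl or 1,2-oxazol-5-yl group at the same carbon would help to separate. Also open, from the compounds shown here alone, is how the 1,2-thiazol-5-yl ring reads in this assay when it carries a methyl group, a fluorine, an amine or a carboxylic acid.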